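A few compounds are considered here, and "the series" means these few. Any claim that something is new, unique, unknown or untested is made for them only; others in the source may bear on it.

Going by the values given here, compound 3 `CC(C)Oc1ccc(C(=O)NCc2ccc(NS(C)(=O)=O)cc2Cl)cc1` gives 400 nM in an assay on HeLa cells for agonist activity at Bile acid receptor (Homo sapiens), read by a luciferase reporter, with a stated time of 24 h (a lower number here means that less compound is needed, a higher number that more compound is needed for the effect), the lowest of the three numbers so far: compound 1 `CN(C)c1ccc(C(=O)NCc2ccc(NS(C)(=O)=O)cc2Cl)cc1` gives 1460 nM and compound 2 `CCOc1ccc(C(=O)NCc2ccc(NS(C)(=O)=O)cc2Cl)cc1` gives 2200 nM. The steps of a 3.7-fold lower number from compound 1 to compound 3 (0.56 log units; beyond the scatter) and a 5.5-fold lower number from compound 2 to compound 3 (0.74 log units; beyond the scatter) both end at the isopropoxy compound with a lower number, while a 1.5-fold higher number from compound 1 to compound 2 (0.18 log units; within the scatter) is within the scatter. Compound 4 `CC(C)(O)c1ccc(C(=O)NCc2ccc(NS(C)(=O)=O)cc2Cl)cc1` differs from compound 3 by 1-hydroxy-1-methylethyl in place of isopropoxy on an aromatic carbon. Among the compounds with values here, no measured step covers this exact change; the two steps toward compound 3 show only that each other group tried at this carbon gave a modestly higher number. A modest step toward a higher number is therefore expected, a 2.5-fold higher number from compound 3 to compound 4 (0.40 log units; beyond the scatter). Compound 4 is estimated at 1000 nM, with a range from 400 nM to 2500 nM.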

Compound 4, half-maximal effective concentration: 32 nM
Compound 4: the middle estimate sits 31-fold (1.49 log units) above what was measured, outside the stated range (below it).
By their numbers in this assay, from the lowest: compound 4; then compound 3; then compounds 1 and 2 (each within the scatter of the next).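

At this aromatic carbon, para to a large group, the same atoms joined differently give a large change in this assay: a 13-fold lower number from compound 3 to compound 4 (1.10 log units; beyond the scatter), and the entering 1-hydroxy-1-methylethyl carries a hydrogen-bond donor that isopropoxy lacks. The steps of a 69-fold lower number from compound 2 to compound 4 (1.84 log units; beyond the scatter) and a 46-fold lower number from compound 1 to compound 4 (1.66 log units; beyond the scatter) are also large, so the position tolerates far more change than the modest differences among the earlier groups suggested. Nothing shown here bears on the reason for this result.

The compounds shown leave open whether the hydroxyl is needed, which a tert-butyl group at this carbon would test. They also leave open whether a hydroxymethyl group or a carboxylic acid would serve there as well.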